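Methoxy on the aryl hydrazine of a pyranone anti-inflammatory scaffold

The compounds below may be only part of what the source reports. "The series", "measured", "known", "first", "only" and "open" are said of these compounds alone.

Measured so far:
compound 1, `CC(=O)c1c(NNc2ccccc2)cc(C)oc1=O`, 57.3%
compound 2, `CC(=O)c1c(NNc2ccc(Br)cc2)cc(C)oc1=O`, 47.2%

In a functional assay on the whole organism for inhibition, with Rattus norvegicus as the target, read by paw edema, with a stated time of 2 h, at a dose of 50 mg/kg (on this read-out lower numbers stand for less inhibition and higher numbers for more inhibition at the one dose given (going by the name of the read-out)), compound 1 gives 57.3%, which is the higher of the two numbers recorded. Among the compounds with values here, compound 2, `CC(=O)c1c(NNc2ccc(Br)cc2)cc(C)oc1=O`, carries bromo in place of hydrogen on an aromatic carbon and in this assay gives 47.2%; the single step known is a number 10.1 percentage points lower from compound 1 to compound 2 (beyond the scatter), a modest loss that lies beyond the scatter.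

Compound 3, `COc1ccc(NNc2cc(C)oc(=O)c2C(C)=O)cc1`, differs from compound 1 by methoxy in place of hydrogen on an aromatic carbon. Within the data shown here, the only measured step that bears on this change is the one from compound 1 to compound 2, where a different group entered at an aromatic carbon of the same ring and the inhibition fell modestly. Among the measured compounds shown here, no step with a methoxy group exists among the measured compounds, so the direction for compound 3 cannot be read from the data with confidence. On that basis the expectation for compound 3 is a step of a number 5.3 percentage points lower from compound 1 to compound 3 (within the scatter), at the edge of the scatter. Compound 3 is therefore estimated at 52% in this assay, with a range from 40% to 64%.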

Compound 3, a percentage reported as inhibition, in the whole organism at one dose (the size of the read-out at that dose, not a potency): 49.4%
Estimate against measurement, compound 3: 2.6 percentage points above, within the range that was stated.
By their numbers in this assay, from the lowest: compounds 2, 3 and 1 (each within the scatter of the next, the first and the last beyond it).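

In this assay, putting methoxy in place of hydrogen on the aromatic carbon para to a large group gives a number 7.9 percentage points lower from compound 1 to compound 3 (within the scatter), so this change, unlike the bromo change, has no effect that can be told from the scatter. Exchanging bromo for methoxy at that same place gives a number 2.2 percentage points higher from compound 2 to compound 3 (within the scatter), which leaves compound 3 within the scatter of both its neighbours, even though the step between those two neighbours, a number 10.1 percentage points lower from compound 1 to compound 2 (beyond the scatter), lies beyond it. The data shown offer no measurement that could explain these numbers.

On these data alone, with only bromo and methoxy at this place, it remains open whether a group here generally lowers the inhibition or whether the bromo result stands apart from a methoxy result that may simply match the unsubstituted compound. An amine, a carboxylic acid or a longer chain such as butoxy at the same aromatic carbon would test whether the read-out stays in this narrow band or moves clearly away from it.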